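This account rests on a few compounds, and the source may have more. Where it says the series, first, only, none or still open, it means among the compounds named here.

Measured so far:
compound 1 `CCNC(=O)c1nc(-c2cc(OC)c(OC)c(OC)c2)n(-c2ccc(OC)cc2)n1` — 88%
compound 2 `COc1ccc(NC(=O)c2nc(-c3cc(OC)c(OC)c(OC)c3)n(-c3ccc(OC)cc3)n2)cc1` — 86%
compound 3 `COc1ccc(-n2nc(C(=O)Nc3cccc(F)c3)nc2-c2cc(OC)c(OC)c(OC)c2)cc1` — 92%

In a functional assay on the whole organism for inhibition, with Rattus norvegicus as the target, read by paw edema, with stated times of 30 min and 3 h, at a dose of 0.28 mmol/kg by the oral route (a higher number here means more inhibition at the dose given (going by the name of the read-out), a lower number less inhibition), compound 1 gives 88%, the second highest of the three numbers. Compound 2 gives 86% and compound 3 gives 92%; the steps of a number 2 percentage points lower from compound 1 to compound 2 (within the scatter), a number 4 percentage points higher from compound 1 to compound 3 (within the scatter) and a number 6 percentage points higher from compound 2 to compound 3 (within the scatter) all stay within the scatter, so the three read as one level.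

Compound 4 is `COc1ccc(-n2nc(C(=O)Nc3ccc(C(F)(F)F)cc3)nc2-c2cc(OC)c(OC)c(OC)c2)cc1`. Relative to compound 1 the change is 4-(trifluoromethyl)phenyl in place of ethyl on an amide-type nitrogen. Among the measured compounds shown here, the steps that bear on it are those where an aryl group replaced ethyl on the same amide-type nitrogen: a number 2 percentage points lower from compound 1 to compound 2 (within the scatter) and a number 4 percentage points higher from compound 1 to compound 3 (within the scatter), neither beyond the scatter. No step beyond the scatter is therefore expected for compound 4, and its estimated step is a number 1 percentage points higher from compound 1 to compound 4 (within the scatter). The estimate for compound 4 in this assay is 89%, with a range of 80% to 96%.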

Compound 4, a percentage reported as inhibition, in the whole organism at one dose (the size of the read-out at that dose, not a potency): 83%
The estimate for compound 4 lay 6 percentage points above the measured number; the measured number falls inside the stated range.
By their numbers in this assay, from the lowest: compounds 4, 2, 1 and 3 (each within the scatter of the next).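

In this assay the amide-type nitrogen also accepts 4-(trifluoromethyl)phenyl, a third aryl group, with every new step within the scatter (a number 5 percentage points lower from compound 1 to compound 4 (within the scatter); a number 9 percentage points lower from compound 3 to compound 4 (within the scatter); a number 3 percentage points lower from compound 2 to compound 4 (within the scatter)). The last step adds that trifluoromethyl in place of methoxy on an aromatic carbon leaves the read-out at the same level, so all four compounds read as one level at this dose. No measured evidence bears on the reason for this.

From the compounds shown here alone, whether a longer chain on this nitrogen, or an amine or carboxylic acid on its aryl ring, would move the number remains open. A single-dose read-out also leaves any difference in potency among these four compounds open.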